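The compounds below may be only part of what the source reports. "The series", "measured", "known", "first", "only" and "open" are said of these compounds alone.

Notes on the series in an ADME assay on Huh-7 cells (Homo sapiens) for cytotoxicity, with a stated time of 72 h; on this read-out lower numbers stand for higher toxicity in this test and higher numbers for lower toxicity in this test. Compound 1 `COCN(c1ccc2c(c1)S(=O)(=O)N=C(c1c(O)c(-c3cccs3)nn(CCC(C)C)c1=O)N2)S(C)(=O)=O` gives > 1000 nM, which is a limit and not a number. Compound 2 `CC(C)CCn1nc(-c2ccn(C)c2)c(O)c(C2=NS(=O)(=O)c3cc(NS(C)(=O)=O)ccc3N2)c1=O` gives > 1000 nM, again only a limit, and the two compounds stand together at the limit of > 1000 nM in this assay, at which 2 of the 2 values shown sit. Compound 3 `CC(C)=Cc1nn(CCC(C)C)c(=O)c(C2=NS(=O)(=O)c3cc(NS(C)(=O)=O)ccc3N2)c1O` has 2-methylprop-1-en-1-yl in place of 1-methyl-1H-pyrrol-3-yl on an aromatic carbon, ortho to a hydroxy group (2-methylprop-1-en-1-yl in place of 1-methyl-1H-pyrrol-3-yl on an aromatic carbon). Among the compounds with values here, the series offers no measured step to scale this change. The estimate is a step that the limit leaves unreadable from compound 2 to compound 3, so no step beyond the scatter is expected. For compound 3 the expected value is 1500 nM, with an estimated range of 700 nM to 6000 nM.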

Compound 3, half-maximal cytotoxic concentration: > 1000 nM
Compound 3: a limit, no number; the forecaster's own chance of this, stated with the estimate: 75%; the middle value is on the limit's open side.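

The step from compound 2 to compound 3 cannot be read, as both values are limits. The compounds shown leave open whether any of these group changes shifts the read-out in this assay: the limit of > 1000 nM in this assay, at which 3 of the 3 values shown sit.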